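Removing chloro on a longer-chain analogue: an expected weakening

The source may hold more compounds than are shown below. What is called first, only, known or untested is meant among the compounds shown, and "the series" means these compounds.

Measured compounds in a functional assay on MDA-MB-231 cells (Homo sapiens) for antiproliferative activity, read by MTT assay, with a stated time of 72 h; a lower number here means a stronger inhibitor, a higher number a weaker inhibitor:
- Compound 1, `CN(C)CCn1cnnc1-c1cc(Oc2ccc(NC(=O)Nc3ccc(Cl)c(C(F)(F)F)c3)cc2F)ccn1`: 1070 nM
- Compound 2, `CN(C)CCn1cnnc1-c1cc(Oc2ccc(NC(=O)Nc3cccc(C(F)(F)F)c3)cc2F)ccn1`: 16400 nM
- Compound 3, `CN(C)CCCn1cnnc1-c1cc(Oc2ccc(NC(=O)Nc3ccc(Cl)c(C(F)(F)F)c3)cc2F)ccn1`: 7880 nM

Compound 4, `CN(C)CCCn1cnnc1-c1cc(Oc2ccc(NC(=O)Nc3cccc(C(F)(F)F)c3)cc2F)ccn1`, has not yet been measured.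

Compound 1 and compound 2 differ in one spot: hydrogen in place of chloro on an aromatic carbon. That change gave a 15-fold higher number from compound 1 to compound 2 (1.19 log units; beyond the scatter), so in this series losing the chloro clearly weakened the compound.

Compound 1 and compound 3 differ in their core: (dimethylamino)methyl in place of dimethylamino on a saturated chain carbon, two bonds along the chain from an aromatic nitrogen. This lengthening gave a 7.4-fold higher number from compound 1 to compound 3 (0.87 log units; beyond the scatter), so compound 3 starts from a weaker position than compound 1. Against compound 2, compound 3 gives the lower number of the two.

Compound 4 relates to compound 3 exactly as compound 2 relates to compound 1: hydrogen in place of chloro on an aromatic carbon. The place of the change is the same in both pairs, so this is the same change applied to the longer-chain core. Going by the values given here, only one example of it has been measured, so its size on the new core is uncertain. It is expected that the step from compound 3 to compound 4 is a 7.6-fold higher number from compound 3 to compound 4 (0.88 log units; beyond the scatter), resting on the weakening seen in a 15-fold higher number from compound 1 to compound 2 (1.19 log units; beyond the scatter) and on compound 3 already standing at 7880 nM.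

Compound 4 is therefore estimated at 60000 nM, with a likely range from 20000 nM to 150000 nM; a value this high may well be reported only as a limit of this assay.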

Compound 4, half-maximal inhibitory concentration: 13300 nM
Estimate against measurement, compound 4: 4.5-fold (0.65 log units) above, outside the stated range (below it).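

In this assay, replacing the chloro with hydrogen on the longer-chain core gave a 1.7-fold higher number from compound 3 to compound 4 (0.23 log units; within the scatter), so the clear loss seen on the shorter-chain core did not reappear, and the two steps differ: the same change on two cores in this assay, a 15-fold higher number (1.19 log units; beyond the scatter) from compound 1 to compound 2 and a 1.7-fold higher number (0.23 log units; within the scatter) from compound 3 to compound 4, 9.1-fold (0.96 log units) apart, beyond the scatter of two such steps

The same four compounds can be read the other way: with no chloro present, lengthening the chain gave a 1.2-fold lower number from compound 2 to compound 4 (0.09 log units; within the scatter), whereas with the chloro present the lengthening had a clear cost, and again the two steps differ: the same change on two cores in this assay, a 7.4-fold higher number (0.87 log units; beyond the scatter) from compound 1 to compound 3 and a 1.2-fold lower number (0.09 log units; within the scatter) from compound 2 to compound 4, 9.1-fold (0.96 log units) apart, beyond the scatter of two such steps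

Going by these compounds alone, the size of this change therefore cannot simply be carried from one core to the other, since each of the two changes counted for much less once the other was in place, but with only one pair on each core, this does not show how general that behaviour is or what lies behind it.

Still open, from the compounds shown here alone, is whether a longer chain, or another amine in place of dimethylamino, would follow compound 3 and compound 4 or compound 1 and compound 2. Going by these compounds, it is also open how a fluoro or a methyl in place of the chloro would behave on either core, and whether this picture would hold in any read-out other than this assay.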